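Fluorophenyl Hydrazides on a Sulfonamide Scaffold in Breast Cancer Cells

The source may report more compounds than this note shows. Statements on the series, on what has been measured and on what is new or still open speak of the compounds shown alone.

Compound 1 `O=C(NNC(=O)c1ccccc1F)c1cccc(NS(=O)(=O)c2cnc(O)nc2O)c1` was tested in a functional assay on MDA-MB-231 cells (Homo sapiens) for antiproliferative activity, read by MTT assay, with a stated time of 24 h; on this read-out lower numbers stand for stronger inhibition and higher numbers for weaker inhibition. In this assay compound 1 reaches only the limit > 20000 nM. Compound 2 `O=C(NNC(=O)c1cccc(NS(=O)(=O)c2cnc(O)nc2O)c1)c1ccc(F)cc1` carries 4-fluorophenyl in place of 2-fluorophenyl on a carbonyl carbon. In this assay compound 2 likewise gives only the limit > 20000 nM. The step that the two limits leave unreadable from compound 1 to compound 2 cannot be sized, since (the limit of > 20000 nM in this assay, at which 3 of the 3 values shown sit). Compound 3 `O=C(NNC(=O)c1ccccc1NS(=O)(=O)c1cnc(O)nc1O)c1ccccc1F` has a core whose difference from the core of compound 1 is not broken down here. In this assay compound 3 also stops at the limit > 20000 nM. Compound 4 `O=C(NNC(=O)c1ccccc1NS(=O)(=O)c1cnc(O)nc1O)c1ccc(F)cc1` is the untested member, carrying (4-fluorophenyl in place of 2-fluorophenyl on a carbonyl carbon), the same change seen from compound 1 to compound 2. The step that the limit leaves unreadable from compound 3 to compound 4 is expected to be unreadable as well, because of the limit of > 20000 nM in this assay, at which 3 of the 3 values shown sit. Compound 4 is therefore estimated at 30000 nM, between 15000 nM and 70000 nM.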

Compound 4, half-maximal inhibitory concentration: > 20000 nM
Compound 4 ended at the assay's limit; the forecaster's own chance of this, stated with the estimate: 85%; the middle value is on the limit's open side.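

With compound 4 also at the limit, no step can be read from compound 3 to compound 4: the limit of > 20000 nM in this assay, at which 4 of the 4 values shown sit.

The compounds shown leave open whether 4-fluorophenyl in place of 2-fluorophenyl changes activity in this assay at all.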